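Methylamino to Methyl: Expected Effect on Hepatocyte Clearance

A few compounds are considered here, and "the series" means these few. Any claim that something is new, unique, unknown or untested is made for them only; others in the source may bear on it.

Two compounds have so far been run in an ADME assay on cells (Hepatocyte, Homo sapiens) for metabolic stability, read by LC-MS, with a stated time of 90 min, tested at 1 uM; on this read-out lower numbers stand for slow clearance and higher numbers for fast clearance. Compound 1 `CC(C)n1nc(-c2ccc3oc(N)nc3c2)c2cnc(N)nc21` carries a free amino on its core, and in this assay compound 1 gives 150 uL/min. Compound 2 `CNc1nc2c(c(-c3ccc4oc(N)nc4c3)nn2C(C)C)c(=O)[nH]1` has a different core, and in this assay compound 2 gives < 5 uL/min, which is a limit of the assay and not a number. Compound 2 therefore stands at the limit of < 5 uL/min in this assay, at which 1 of the 2 values shown sits, at the slow end of the two values shown, whereas compound 1 lies far from that limit. For the measured compounds named here, the two compounds differ in more than one place, so their values show only that compound 1 is cleared quickly and compound 2 slowly.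

Compound 3 `Cc1nc2c(c(-c3ccc4oc(N)nc4c3)nn2C(C)C)c(=O)[nH]1` has not yet been measured. It differs from compound 2 in a single place: methyl in place of methylamino on an aromatic carbon. Compound 2 already sits at the limit, and only a modest shift toward faster clearance, if any, is anticipated, so the step is expected to be an at least 1.6-fold higher number from compound 2 to compound 3 (0.20 log units; that floor lies within the scatter). In this assay compound 3 is expected to give 8 uL/min, with a likely range from 3 uL/min to 25 uL/min.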

Compound 3, intrinsic clearance in a liver preparation (reported as CLH), per the amount of preparation that the assay uses in the Hepatocyte assay: < 5 uL/min
Compound 3: only a limit was reported (the forecaster's own chance of this, stated with the estimate: 40%); middle value at least 1.6-fold (0.20 log units) away from the limit.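

For the compounds shown here, in the Hepatocyte assay compound 2 and compound 3 both stand at a limit of the assay, and no step between them can be read. In a physicochemical assay for solubility, read by HPLC, in phosphate buffer, measured as kinetic solubility, with a stated time of 24 h, at 20 degrees C, at pH 7.4, tested at 100 uM (on this read-out lower numbers stand for lower solubility and higher numbers for higher solubility), compound 2 gives < 1000 nM, which is a limit and not a number. In the physicochemical assay compound 3 gives 3000 nM. From the compounds shown here alone, how fast compound 2 and compound 3 are actually cleared remains open.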